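The source may hold more compounds than are shown below. What is called first, only, known or untested is meant among the compounds shown, and "the series" means these compounds.

Working notes on the series. Compound 1 `Cc1ccccc1-n1nncc1CN1C(=O)C2(C(C#N)=C(N)Oc3c(N)cc4nc5ccccc5nc4c32)c2ccccc21` reaches only the assay limit in a functional assay on MCF7 cells (Homo sapiens) for antiproliferative activity, read by MTT assay, with a stated time of 48 h (a lower number here means a stronger inhibitor, a higher number a weaker inhibitor), recorded as > 50000 nM, a limit and not a number. Compound 2 `COc1ccccc1-n1nncc1CN1C(=O)C2(C(C#N)=C(N)Oc3c(N)cc4nc5ccccc5nc4c32)c2ccccc21` gives 28900 nM in this assay. Compound 3 `N#CC1=C(N)Oc2c(N)cc3nc4ccccc4nc3c2C12C(=O)N(Cc1cnnn1-c1ccc(Cl)cc1Cl)c1ccccc12` likewise returns only a limit in this assay, > 50000 nM. Compound 3 thus stands at the boundary of what this assay reports, as does one further value, and the limit of > 50000 nM in this assay, at which 2 of the 3 values shown sit, marks the boundary shared by both. Among the measured pairs, an at least 1.7-fold lower number from compound 1 to compound 2 (0.23 log units; that floor lies within the scatter); a step that the two limits leave unreadable from compound 1 to compound 3; and an at least 1.7-fold higher number from compound 2 to compound 3 (0.23 log units; that floor lies within the scatter).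

Compound 4 `N#CC1=C(N)Oc2c(N)cc3nc4ccccc4nc3c2C12C(=O)N(Cc1cnnn1-c1ccc(Cl)cc1[N+](=O)[O-])c1ccccc12` differs from compound 3 by nitro in place of chloro on an aromatic carbon. Among the compounds with values here, no measured step touches this position: the two steps ending at compound 3, a step that the two limits leave unreadable from compound 1 to compound 3 and an at least 1.7-fold higher number from compound 2 to compound 3 (0.23 log units; that floor lies within the scatter), exchange the whole group on the aromatic nitrogen and leave compound 3 at a limit. The expected step is therefore a number no higher from compound 3 to compound 4 (the limit leaves the size open), nothing beyond the scatter, with the limit again the likelier report. Compound 4 is expected near 50000 nM, in a range from 20000 nM to 150000 nM.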

Compound 4, half-maximal inhibitory concentration: > 50000 nM
Compound 4: no number, only a limit; the forecaster's own chance of this, stated with the estimate: 70%; the middle value sits exactly at the limit.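

Nitro in place of chloro, at the place ortho to a large group, does not bring a number in this assay: compound 4 gives only a limit, and no step between two limits can be read. Within the data shown here, the one readable step is an at least 1.7-fold higher number from compound 2 to compound 4 (0.23 log units; that floor lies within the scatter), so this is a floor and does not separate the 4-chloro-2-nitrophenyl group from the 2-methoxyphenyl group. The change adds a third compound at the same boundary: the limit of > 50000 nM in this assay, at which 3 of the 4 values shown sit.

On these data alone, how far compound 1, compound 3 and compound 4 lie beyond that limit remains open, and so does any ranking of their groups. Also open, as far as these compounds go, is whether an amine or a carboxylic acid at this place on the ring would give a number in this assay.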